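Swapping cyclopropylmethyl for tert-butyl on compound 2

A few compounds are considered here, and "the series" means these few. Any claim that something is new, unique, unknown or untested is made for them only; others in the source may bear on it.

Measured in an ADME assay on Caco-2 cells (Homo sapiens) for permeability, read by LC-MS, in the apical to basolateral direction, with a stated time of 60 min, at pH 6.5; a lower number here means that the compound crosses the layer more slowly, a higher number that the compound crosses the layer faster:
compound 1 `O=C(NCc1cc(Cl)ccc1-n1cnnn1)[C@@H]1C[C@@H]2C[C@@H]2N1C(=O)[C@H](O)CC1CC1` gives 3.6 10^-6 cm/s
compound 2 `O=C(NCc1cc(Cl)ccc1-n1cnnn1)[C@@H]1C[C@H]2C[C@H]2N1C(=O)[C@H](O)CC1CC1` gives 6.9 10^-6 cm/s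
compound 3 `CC(C)(C)[C@@H](O)C(=O)N1CC(=O)C[C@H]1C(=O)NCc1cc(Cl)ccc1-n1cnnn1` gives 0.8 10^-6 cm/s

Compound 2 sits within the scatter of compound 1 and clearly higher than compound 3. Compound 4 `CC(C)(C)[C@@H](O)C(=O)N1[C@@H]2C[C@@H]2C[C@H]1C(=O)NCc1cc(Cl)ccc1-n1cnnn1` has tert-butyl in place of cyclopropylmethyl on a saturated chain carbon bound to a carbonyl carbon and an oxygen on a saturated carbon

Within the data shown here, the only measured step, a 1.9-fold higher number from compound 1 to compound 2 (0.28 log units; within the scatter), changes configuration alone and so does not test this swap. Compound 3 also carries tert-butyl, but on a different core, so its low value cannot be read as the effect of that group. Expected is a small change, within the scatter: a 1.3-fold lower number from compound 2 to compound 4 (0.10 log units; within the scatter).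

For compound 4 the estimate is 5.5 10^-6 cm/s, expected between 2.5 10^-6 cm/s and 12 10^-6 cm/s.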

Compound 4, apparent permeability: 34 10^-6 cm/s
For compound 4 the middle estimate is 6.2-fold (0.79 log units) below the measured one; the measured number lies above the stated range.
By their numbers in this assay, from the lowest: compound 3; then compounds 1 and 2 (each within the scatter of the next); then compound 4.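

On the core of compound 2, tert-butyl in place of cyclopropylmethyl is not a neutral exchange in this assay: the change gives a 4.9-fold higher number from compound 2 to compound 4 (0.69 log units; beyond the scatter). This is the first step shown that tests this group, and it lies beyond the scatter although both groups have the same count of heavy atoms. Nothing measured here accounts for the rise.

The compounds shown leave open whether the rise carries over to the core of compound 3. They also leave open how a longer chain or an amine in this place would read.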